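Swapping One Halogenated Phenyl Group for Another

This account rests on a few compounds, and the source may have more. Where it says the series, first, only, none or still open, it means among the compounds named here.

Of the compounds shown here, three have so far been measured in a functional assay, with a stated time of 20 min; on this read-out higher numbers stand for weaker inhibition and lower numbers for stronger inhibition. Compound 1, `CCOC(=O)c1cnn(-c2nc(-c3ccccc3F)c(C#N)c(=O)n2C)c1N`, gives 69 ug/mL. Compound 2, `CN(C)c1ccc(-c2nc(NN)n(C)c(=O)c2C#N)cc1`, gives 81 ug/mL, and compound 3, `Cn1c(NN)nc(-c2cccc(O)c2O)c(C#N)c1=O`, gives 34 ug/mL. Among these three numbers compound 1 holds the second highest place; compound 2 sits within the usual scatter of it, so the two cannot be told apart, while compound 3 shows a lower number that lies beyond the scatter. No pair of these compounds differs in only one place, so none of the gaps between them can be tied to a single structural change.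

Compound 4, `CCOC(=O)c1cnn(-c2nc(-c3ccc(Cl)cc3)c(C#N)c(=O)n2C)c1N`, differs from compound 1 in one place: 4-chlorophenyl in place of 2-fluorophenyl on an aromatic carbon. Going by the values given here, nothing in the measured set shows how this assay responds to such a swap, so the expectation rests on the single anchor of compound 1 alone. Compound 4 is therefore expected to give about 60 ug/mL, with a likely range from 25 ug/mL to 150 ug/mL. The step this estimate implies, a 1.2-fold lower number from compound 1 to compound 4 (0.06 log units; within the scatter), is expected to stay within the usual scatter.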

Compound 4, half-maximal inhibitory concentration: 64 ug/mL
Beside the measured number, compound 4's estimate is 1.1-fold (0.03 log units) below it; the measured number falls inside the stated range.
By their numbers in this assay, from the lowest: compounds 3, 4, 1 and 2 (each within the scatter of the next, the first and the last beyond it).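

In this assay, going by these compounds alone, the first comparison in this set that differs in only one place gives a 1.1-fold lower number from compound 1 to compound 4 (0.03 log units; within the scatter), so 4-chlorophenyl and 2-fluorophenyl cannot be told apart at this aromatic carbon. This swap changes both the halogen and where it sits on the phenyl group, and the two changes cannot be separated here: neither may matter, or their influences may offset each other. No measured evidence bears on this result, so the match remains unexplained.

Going by these compounds, it remains open whether this position responds to any change at all, since both groups compared are halogenated phenyl groups of the same size. A plain phenyl group would show whether the halogen matters, and a phenyl group carrying a carboxylic acid would test a very different substituent.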